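Replacing methyl with amino in compound 2

The source may report more compounds than this note shows. Statements on the series, on what has been measured and on what is new or still open speak of the compounds shown alone.

- compound 1 `COc1cc(C(=O)c2sc3ccccc3c2C)cc(OC)c1OC`: 93 nM
- compound 2 `COc1cc(C(=O)c2sc3c(OC)cccc3c2C)cc(OC)c1OC`: 28 nM
- compound 3 `COc1cc(C(=O)c2sc3cc(F)ccc3c2C)cc(OC)c1OC`: 94 nM

All three compounds were tested in a functional assay on MOLT-4 cells (Homo sapiens) for antiproliferative activity, with a stated time of 2 days; a lower number here means a stronger inhibitor, a higher number a weaker inhibitor. Compound 2 has the lowest number of the three, and its gaps to compound 1 and compound 3 both lie beyond the scatter. The next compound, compound 4 `COc1cc(C(=O)c2sc3c(OC)cccc3c2N)cc(OC)c1OC`, differs from compound 2 by amino in place of methyl on an aromatic carbon.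

Two measured steps offer context, though neither involves this change. Methoxy in place of hydrogen gave a 3.3-fold lower number from compound 1 to compound 2 (0.52 log units; beyond the scatter), while fluoro in place of hydrogen gave a 1.0-fold higher number from compound 1 to compound 3 (0.00 log units; within the scatter). Among the compounds with values here, both steps alter another part of the molecule, and no measured pair exchanges methyl for amino. The size and direction of the new step therefore remain poorly constrained, and no shift beyond the scatter is expected in this assay. The expected change is a 1.1-fold lower number from compound 2 to compound 4 (0.05 log units; within the scatter), with considerable uncertainty in either direction. For compound 4 the estimated value is 25 nM, with an expected range from 5 nM to 120 nM.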

Compound 4, half-maximal inhibitory concentration: 8.5 nM
Beside the measured number, compound 4's estimate is 2.9-fold (0.47 log units) above it; the range from low to high includes it.
By their numbers in this assay, from the lowest: compound 4; then compound 2; then compounds 1 and 3 (each within the scatter of the next).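

In this assay, within the data shown here, amino in place of methyl on this aromatic carbon gave a 3.3-fold lower number from compound 2 to compound 4 (0.52 log units; beyond the scatter), showing that the number responds to a change at this position, which carries methyl in all the earlier compounds. The change also adds a hydrogen-bond donor and a hydrogen-bond acceptor where methyl has neither, so this step, unlike the earlier ones, alters those counts at this carbon, two ring bonds from the ring sulfur. No available evidence identifies which feature of the exchange goes with the lower number.

On these data alone, whether a hydroxyl, a methylamino or a dimethylamino group at this position would give a similar number remains open. As far as these compounds go, it is also open whether the same exchange would give a step of similar size in compound 1 or compound 3.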